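Formalin test notes: aryl swap on the urea of compound 3

The source may report more compounds than this note shows. Statements on the series, on what has been measured and on what is new or still open speak of the compounds shown alone.

Measured so far:
- compound 1, `CCN1CCc2c(c(C)nn2C(=O)Nc2ccc(Br)cc2)C1`: 1.7%
- compound 2, `CCN1CCc2c(c(C)nn2C(=O)Nc2ccc(F)cc2F)C1`: 7.8%
- compound 3, `CCN1CCc2c(c(C(C)(C)C)nn2C(=O)Nc2ccc(Br)cc2)C1`: 0%

In a functional assay on the whole organism (strain Swiss albino) for inhibition, with Mus musculus as the target, in the formalin test, with stated times of 30 min and 5 min, at a dose of 100 mg/kg (on this read-out higher numbers stand for more inhibition at the one dose given (going by the name of the read-out) and lower numbers for less inhibition), compound 3 gives the lowest of the three numbers, though its gap to compound 1 and to compound 2 is within the scatter, so no order among the three can be read. Among the measured compounds shown here, the only single-place step measured is tert-butyl in place of methyl on an aromatic carbon, a number 1.7 percentage points lower from compound 1 to compound 3 (within the scatter), which left the read-out essentially unchanged.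

Compound 4, `CCN1CCc2c(c(C(C)(C)C)nn2C(=O)Nc2cc(C)ccc2C)C1`, differs from compound 3 at the aryl on the urea: 2,5-dimethylphenyl in place of 4-bromophenyl on an amide-type nitrogen. For the measured compounds named here, no measured step touches this position; compound 1 and compound 2 carry different aryls, and their values in this assay are simply both low, with nothing further to be drawn. Going by the values given here, with every number near the floor and the one measured step flat, the expectation for a number 3 percentage points higher from compound 3 to compound 4 (within the scatter) is no change beyond the scatter. Compound 4 is therefore estimated at 3%, with a range of 0% to 14%.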

Compound 4, a percentage reported as inhibition, in the whole organism at one dose (the size of the read-out at that dose, not a potency): 0%
Compound 4: the middle estimate sits 3 percentage points above what was measured; the measured number falls inside the stated range.
By their numbers in this assay, from the lowest: compounds 3, 4, 1 and 2 (each within the scatter of the next).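

At the aryl on an amide-type nitrogen, 2,5-dimethylphenyl in place of 4-bromophenyl in this assay gives no change at the digits printed from compound 3 to compound 4 (within the scatter). Among the compounds shown here, this is the first step read at this position, as the only earlier step lay at the aromatic carbon carrying methyl or tert-butyl; on the tert-butyl compounds, exchanging a bromine-bearing aryl for a dimethyl-substituted one leaves the read-out at the floor. Nothing in hand bears on the reason for this flat result.

Still open, as far as these compounds go, is whether an aryl carrying an amine or a carboxylic acid, or a cyclohexyl group in place of the aryl, would move the read-out off the floor at this position. Also open, from the compounds shown here alone, is whether 2,5-dimethylphenyl would read the same with methyl rather than tert-butyl on the aromatic carbon.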